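The source may report more compounds than this note shows. Statements on the series, on what has been measured and on what is new or still open speak of the compounds shown alone.

Three compounds share one core and differ only in the group on the aromatic nitrogen of the pyrazole ring. Compound 1 `Cc1c(Nc2nc(N)c3c(C#N)c(N4CCC[C@H]4C)n(C)c3n2)cnn1C` carries a 1,5-dimethyl-1H-pyrazol-4-yl group and, in an assay on HEK293 cells for inhibition of Leucine-rich repeat serine/threonine-protein kinase 2 (Homo sapiens), with a stated time of 48 h (on this read-out higher numbers stand for weaker inhibition and lower numbers for stronger inhibition), compound 1 gives 310 nM. Compound 2 `Cc1nn(C2COC2)cc1Nc1nc(N)c2c(C#N)c(N3CCC[C@H]3C)n(C)c2n1` carries a 3-methyl-1-(oxetan-3-yl)-1H-pyrazol-4-yl group, and in this assay compound 2 gives 240 nM. Compound 3 `C[C@@H]1CCCN1c1c(C#N)c2c(N)nc(Nc3cn(C)nc3C(F)(F)F)nc2n1C` carries a 1-methyl-3-(trifluoromethyl)-1H-pyrazol-4-yl group, and in this assay compound 3 gives 910 nM. Compound 2 thus gives the lowest of the three numbers, yet its gap to compound 1 is within the scatter, so only compound 3 stands apart from it, with a 3.8-fold higher number from compound 2 to compound 3 (0.58 log units; beyond the scatter) and a 2.9-fold higher number from compound 1 to compound 3 (0.47 log units; beyond the scatter).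

The unmeasured compound 4 `Cc1nn(CC2(O)COC2)cc1Nc1nc(N)c2c(C#N)c(N3CCC[C@H]3C)n(C)c2n1` differs from compound 2 by (3-hydroxyoxetan-3-yl)methyl in place of oxetan-3-yl on an aromatic nitrogen. For the measured compounds named here, the one measured step that alters the group on that same nitrogen is a 1.3-fold lower number from compound 1 to compound 2 (0.11 log units; within the scatter), which was within the scatter. The two modest steps toward compound 3 concern the trifluoromethyl group and do not bear on this change. Going by the values given here, with no measured step pointing either way, he expects compound 4 to move by a 1.1-fold higher number from compound 2 to compound 4 (0.05 log units; within the scatter) in this assay, no change beyond the scatter. His estimate for compound 4 is 270 nM, within a range from 110 nM to 650 nM.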

Compound 4, half-maximal inhibitory concentration: 410 nM
For compound 4 the middle estimate is 1.5-fold (0.18 log units) below the measured one, within the range that was stated.
By their numbers in this assay, from the lowest: compounds 2, 1 and 4 (each within the scatter of the next); then compound 3.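

For the compounds shown here, the step of a 1.7-fold higher number from compound 2 to compound 4 (0.23 log units; within the scatter) is the first here in which only the group on the aromatic nitrogen changes while the methyl group on the ring stays in place, since the earlier steps each replaced the whole pyrazolyl group. It shows that, in this assay, this nitrogen can carry (3-hydroxyoxetan-3-yl)methyl, with 6 heavy atoms and 1 hydrogen-bond donor, in place of oxetan-3-yl, with 4 heavy atoms and 0 hydrogen-bond donors, without the two compounds separating beyond the scatter. Nothing in the data shown offers an explanation for this result.

The change adds the methyl linker and the hydroxyl group together, so the compounds shown leave open what each contributes alone, a question that (oxetan-3-yl)methyl or 3-hydroxyoxetan-3-yl on the same nitrogen could address. They also leave open whether this nitrogen would accept an amine, a carboxylic acid or a longer chain and still stay within the scatter of compound 2, or whether such groups would move the number as far as the step to compound 3 does.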